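The compounds below may be only part of what the source reports. "The series", "measured", "known", "first", "only" and "open" are said of these compounds alone.

Measured so far in a functional assay on PC-3 cells (Homo sapiens) for antiproliferative activity, read by sulforhodamine B assay; a higher number here means a weaker inhibitor of growth, a lower number a stronger inhibitor of growth:

- Compound 1 `CC(C)CCCOc1cccc(O)c1C(=O)/C=C/c1ccc(O)cc1`: 3600 nM
- Compound 2 `CC(C)(C)CCOc1cccc(O)c1C(=O)/C=C/c1ccc(C(=O)O)cc1`: 6500 nM
- Compound 3 `CC(C)=CCOc1cccc(O)c1C(=O)/C=C/c1ccc(O)cc1`: > 30000 nM, a limit and not a number

Compound 3 stands at the limit of > 30000 nM in this assay, at which 1 of the 3 values shown sits. Compound 4 `CC(C)CCOc1cccc(O)c1C(=O)/C=C/c1ccc(O)cc1` differs from compound 3 in one place: isobutyl in place of 2-methylprop-1-en-1-yl on a saturated chain carbon bound to an oxygen on an aromatic ring. Isobutyl replaces 2-methylprop-1-en-1-yl on a saturated chain carbon bound to an oxygen on an aromatic ring, so the double bond outside aromatic rings leaves.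

Among the measured compounds shown here, one measured step bears on this: an at least 8.3-fold higher number from compound 1 to compound 3 (0.92 log units; beyond the scatter). It is the same kind of swap, run in the opposite direction, but from isopentyl rather than isobutyl. A clearly lower number is therefore expected in this assay, in the region of compound 1 at 3600 nM. The expected step is an at least 5.0-fold lower number from compound 3 to compound 4 (0.69 log units; beyond the scatter). For compound 4 the estimate is 6000 nM, with an expected range of 2000 nM to 20000 nM.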

Compound 4, concentration for 50% growth inhibition: 11500 nM
The estimate for compound 4 lay 1.9-fold (0.28 log units) below the measured number; the measured number falls inside the stated range.
By their numbers in this assay, from the lowest: compounds 1, 2 and 4 (each within the scatter of the next, the first and the last beyond it). At a limit, above all of these: compound 3.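

In this assay, the change from 3-methylbut-2-en-1-yl to isopentyl removes the double bond while the chain keeps its heavy atom count, and this alone matters, which compound 1 could not show: there is an at least 2.6-fold lower number from compound 3 to compound 4 (0.41 log units; beyond the scatter). Compound 3 stands at a limit and not a number, so the true size of that step stays open: the limit of > 30000 nM in this assay, at which 1 of the 4 values shown sits.

Chain length counts separately, since the saturated chains also differ: there is a 3.2-fold higher number from compound 1 to compound 4 (0.50 log units; beyond the scatter). On these data alone, whether a chain longer than that of compound 1, or a chain carrying an amine, would lower the number further remains open.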